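Replacing a methoxy group by a carboxycarbonylamino group

A few compounds are considered here, and "the series" means these few. Any claim that something is new, unique, unknown or untested is made for them only; others in the source may bear on it.

Measured compounds:
- compound 1, `COc1ccc(CCCCCCCCOc2ccc(CSc3cccc(NS(=O)(=O)C(F)(F)F)c3)nc2/C=C/C(=O)O)cc1`: 284 nM
- compound 2, `COc1ccc(CCCCCCCCOc2ccc(CSc3cccc(N)c3)nc2/C=C/C(=O)O)cc1`: 34 nM
- compound 3, `COc1ccc(CCCCCCCCOc2ccc(CSc3cccc(OC)c3)nc2/C=C/C(=O)O)cc1`: 192 nM

These three compounds share one large core and differ only in one group on the outer benzene ring. Compound 3 stands second highest of the three numbers in an assay for binding affinity to leukotriene B4 receptor 1 (Homo sapiens); on this read-out higher numbers stand for weaker inhibition and lower numbers for stronger inhibition: the step of a 5.6-fold higher number from compound 2 to compound 3 (0.75 log units; beyond the scatter) is beyond the scatter, whereas the step of a 1.5-fold lower number from compound 1 to compound 3 (0.17 log units; within the scatter) stays within it, so compound 3 and compound 1 cannot be told apart on this read-out.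

Compound 4, `COc1ccc(CCCCCCCCOc2ccc(CSc3cccc(NC(=O)C(=O)O)c3)nc2/C=C/C(=O)O)cc1`, is not yet measured. It differs from compound 3 by (carboxycarbonyl)amino in place of methoxy on an aromatic carbon.

The measured steps bear on this change only indirectly. The free amino group of compound 2 gave a clearly lower number than the methoxy group of compound 3, but the acylated nitrogen of compound 1 did not. The new group also carries an acylated nitrogen, so a step of the size seen in a 1.5-fold lower number from compound 1 to compound 3 (0.17 log units; within the scatter) seems the closer guide, and no change beyond the scatter is expected, with the step of a 1.3-fold lower number from compound 3 to compound 4 (0.11 log units; within the scatter) as the estimate. Compound 4 is expected to give 150 nM, between 40 nM and 550 nM.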

Compound 4, inhibition constant: 72 nM
Compound 4: the middle estimate sits 2.1-fold (0.32 log units) above what was measured, within the range that was stated.
By their numbers in this assay, from the lowest: compound 2; then compound 4; then compounds 3 and 1 (each within the scatter of the next).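

In this assay, two groups on the same nitrogen are now told apart: carboxycarbonyl in place of (trifluoromethyl)sulfonyl gives a 3.9-fold lower number from compound 1 to compound 4 (0.60 log units; beyond the scatter), so what sits on that nitrogen matters. With a 2.7-fold lower number from compound 3 to compound 4 (0.43 log units; beyond the scatter), a substituted nitrogen at this place can also give a lower number than methoxy, which compound 1 did not show. Adding carboxycarbonyl to the free amino group still gives a 2.1-fold higher number from compound 2 to compound 4 (0.33 log units; beyond the scatter), so compound 2 keeps the lowest number of the four.

Nothing shown here gives a reason for this order. A simple acetylamino group, or the methyl ester of the carboxycarbonyl group, would show whether the carboxylic acid at the end of the new group is needed for the lower number or the amide alone is enough.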